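The source may hold more compounds than are shown below. What is called first, only, known or untested is meant among the compounds shown, and "the series" means these compounds.

Three compounds that share one core have been examined in a functional assay on WI-38 VA13 cells (Homo sapiens) for cytotoxicity; on this read-out higher numbers stand for an effect only at larger amounts of compound and lower numbers for an effect already at smaller amounts. Compound 1 `Cc1cc(C(=O)Nc2ccc3nc(NC(=O)C4CCCCC4)sc3c2)c(C)n1C` gives only a limit in this assay, > 6.2 ug/mL. Compound 2 `CC(C)CC(=O)Nc1nc2ccc(NC(=O)c3c(Cl)cccc3Cl)cc2s1` gives 0.012 ug/mL. For the measured compounds named here, compound 3 `CC(C)(C)OC(=O)Nc1nc2ccc(NC(=O)c3c(Cl)cccc3Cl)cc2s1` gives 0.027 ug/mL, which places compound 3 highest of the two numbers that were obtained; its nearest neighbour is compound 2, and the step of a 2.3-fold higher number from compound 2 to compound 3 (0.35 log units; beyond the scatter) is the only measured step between compounds that differ in a single place. Compound 4 `COc1ccccc1Nc1nc2ccc(NC(=O)c3c(Cl)cccc3Cl)cc2s1` has not yet been measured. It differs from compound 3 in one place: 2-methoxyphenyl in place of tert-butoxycarbonyl on a nitrogen on an aromatic ring. Going by the values given here, that change sits on the same nitrogen at which compound 2 and compound 3 differ from each other, and the one measured step at that position was modest in size. Among the compounds with values here, no measured step covers an aromatic ring entering at this nitrogen, so the expectation can rest only on the modest size of that single step. On that basis compound 4 is expected to give about 0.04 ug/mL in this assay, with a range from 0.01 ug/mL to 0.2 ug/mL. That estimate amounts to an expected step of a 1.5-fold higher number from compound 3 to compound 4 (0.17 log units; within the scatter), which is anticipated to stay close to the scatter of the measurement.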

Compound 4, half-maximal effective concentration: > 7.2 ug/mL
Compound 4 gave a limit, no number; the forecaster's own chance of this, stated with the estimate: 10%; middle value at least 180-fold (2.25 log units) from the limit.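

The nitrogen on the aromatic ring proves far more sensitive than the earlier pair suggested: in this assay, the change to 2-methoxyphenyl gives an at least 260-fold higher number from compound 3 to compound 4 (2.42 log units; beyond the scatter), and measured against the isobutylcarbonyl group it gives an at least 600-fold higher number from compound 2 to compound 4 (2.77 log units; beyond the scatter). For the compounds shown here, both steps are large, whereas a 2.3-fold higher number from compound 2 to compound 3 (0.35 log units; beyond the scatter) is modest, and in that earlier step a carbonyl stayed on this nitrogen, so the earlier compounds showed only that one such group could replace another with little change. Compound 4 has no carbonyl on this nitrogen and carries an aromatic ring there instead, and its result is a limit of the assay, not a number: the limit of > 7.2 ug/mL in this assay, at which 1 of the 4 values shown sits.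

The compounds shown do not separate the loss of the carbonyl from the arrival of the aromatic ring or of its methoxy group, since all three changes occur together in the same step. As far as these compounds go, a benzoyl group, which would keep the carbonyl and add a ring, an unsubstituted phenyl group and a free amine at this nitrogen would each help to tell these apart, and the size of the step remains open while compound 4 stands as a limit.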